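This account rests on a few compounds, and the source may have more. Where it says the series, first, only, none or still open, it means among the compounds named here.

Measured so far:
compound 1, `CC(C)C(c1ncc[nH]1)c1ccc(-c2ccc3cccc(F)c3c2)[nH]c1=O` — in an ADME assay on microsomes from liver (Rattus norvegicus) for metabolic stability (a lower number here means that the compound disappears faster, a higher number that the compound lasts longer), compound 1 gives < 0.0667 h, a limit of the assay rather than a number.
compound 2, `CC(C)C(/C=C1\CCNC1=O)c1ccc(-c2ccc3cccc(F)c3c2)[nH]c1=O` — in this assay compound 2 gives 0.345 h.

Compound 1 stands at the lower limit of this assay; only a bound is known for it, as the limit of < 0.0667 h in this assay, at which 1 of the 2 values shown sits, shows. Among the compounds with values here, the single measured step, an at least 5.1-fold higher number from compound 1 to compound 2 (0.71 log units; beyond the scatter), swaps the aromatic ring group on the saturated chain carbon for a non-aromatic ring group and moves the value into the measurable range.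

Compound 3, `CC(C)C(c1ccc(-c2ccc3cccc(F)c3c2)[nH]c1=O)N1CCN/C1=N\C#N`, is not yet measured. It differs from compound 1 as follows: a group of 8 heavy atoms (4 carbon, 4 nitrogen; one five-membered non-aromatic ring with 2 hetero atoms) in place of a group of 5 heavy atoms (3 carbon, 2 nitrogen; one five-membered aromatic ring with 2 hetero atoms), on a saturated chain carbon bound to an aromatic carbon and a saturated chain carbon. Within the data shown here, this again replaces the aromatic ring group with a non-aromatic ring group at the same place, so the step of an at least 5.1-fold higher number from compound 1 to compound 2 (0.71 log units; beyond the scatter) is the only measured step that bears on it. A step upward beyond the scatter is therefore expected in this assay, though its size is uncertain because compound 1 sits at the limit (the limit of < 0.0667 h in this assay, at which 1 of the 2 values shown sits). Compound 3 is expected to give about 0.15 h in this assay, in the range 0.05 h to 0.45 h, which is an expected step of an at least 2.2-fold higher number from compound 1 to compound 3 (0.35 log units; beyond the scatter).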

Compound 3, half-life: 0.327 h
Beside the measured number, compound 3's estimate is 2.2-fold (0.34 log units) below it; low and high end bracket the measured number.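

In this assay, a second non-aromatic ring group in place of 1H-imidazol-2-yl, on the same saturated chain carbon, gives an at least 4.9-fold higher number from compound 1 to compound 3 (0.69 log units; beyond the scatter), so the step seen with compound 2 is no longer tied to a single group. Within the data shown here, the two non-aromatic ring groups differ in their atoms, and only the one in compound 3 has a triple bond, yet the step between them is a 1.1-fold lower number from compound 2 to compound 3 (0.02 log units; within the scatter), which leaves compound 2 and compound 3 indistinguishable here. The value of compound 1 is a limit of the assay, so the steps from it give a bound and not a size: the limit of < 0.0667 h in this assay, at which 1 of the 3 values shown sits.

Among these compounds, with 1H-imidazol-2-yl as the only aromatic group at this place, it remains open whether a phenyl or pyridine ring would also stay at the limit. Going by these compounds, it also remains open whether an open-chain amide would do as well as the non-aromatic rings.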